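The source may report more compounds than this note shows. Statements on the series, on what has been measured and on what is new or still open speak of the compounds shown alone.

Measured compounds:
- compound 1, `CCC(Nc1nc(C)nc2c1nnn2-c1ccc(C(C)C)cc1Br)C(=O)OC`: 19.4 nM
- compound 2, `COCCNc1nc(C)nc2c1nnn2-c1ccc(C(C)C)cc1Br`: 242 nM

In an in vitro assay on 293-EBNA cells for binding affinity to corticotropin-releasing factor receptor 1 (Homo sapiens) (on this read-out lower numbers stand for stronger inhibition and higher numbers for weaker inhibition), compound 2 gives the higher of the two numbers, and compound 1 gives the lower one; the step of a 12-fold higher number from compound 1 to compound 2 (1.10 log units; beyond the scatter) came with 2-methoxyethyl in place of 1-(methoxycarbonyl)propyl on a nitrogen on an aromatic ring. Compound 3, `CCCCC(CC)Nc1nc(C)nc2c1nnn2-c1ccc(C(C)C)cc1Br`, is not yet measured. It differs from compound 2 in one place: 1-ethylpentyl in place of 2-methoxyethyl on a nitrogen on an aromatic ring. For the measured compounds named here, the only step that bears on this is a 12-fold higher number from compound 1 to compound 2 (1.10 log units; beyond the scatter), which was large, so the branched group on that nitrogen appears to matter a great deal. Because compound 1, with a branched group on the same nitrogen, gives 19.4 nM, the branched 1-ethylpentyl group in compound 3 is expected to bring the number back down by a large step, a 16-fold lower number from compound 2 to compound 3 (1.21 log units; beyond the scatter). Compound 3 is therefore estimated at 15 nM, within a range of 4 nM to 60 nM.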

Compound 3, inhibition constant: 3.1 nM
For compound 3 the middle estimate is 4.8-fold (0.68 log units) above the measured one, and the stated range ends above it.
By their numbers in this assay, from the lowest: compound 3; then compound 1; then compound 2.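

In this assay, 1-ethylpentyl in place of 2-methoxyethyl on the nitrogen gives a 78-fold lower number from compound 2 to compound 3 (1.89 log units; beyond the scatter), so a low number at this position does not depend on an oxygen in the group, and the all-carbon group gives the lowest number of the three compounds. The methoxycarbonyl of compound 1 is not required either, as butyl in its place gives a 6.3-fold lower number from compound 1 to compound 3 (0.80 log units; beyond the scatter), a modest step beside the large one from the 2-methoxyethyl compound. No measurement shown explains why either change moves the number.

Compound 2 differs from compound 3 in both branching and size, so these compounds cannot show which of the two matters. A straight heptyl chain would test branching, while a carboxylic acid or an amine on the branched group would show how this position responds to other groups.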